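Cyano to propyl on the biaryl tail: effect on activation

The source may report more compounds than this note shows. Statements on the series, on what has been measured and on what is new or still open speak of the compounds shown alone.

Measured so far:
compound 1 `Oc1ccccc1CCc1ccc(C2CCCCC2)cc1` — "not active" (no number reported)
compound 2 `N#Cc1ccc(-c2ccc(NCc3ccccc3O)cc2)cc1` — "not active" (no number reported)
compound 3 `Oc1ccccc1CNc1ccc(-c2ccccc2F)cc1` — 2150 nM

In a functional assay on Jurkat cells (Homo sapiens) for activation, with a stated time of 24 h (on this read-out lower numbers stand for an effect already at smaller amounts and higher numbers for an effect only at larger amounts of compound), compound 2 gives "not active" (no number reported). It therefore stands without a single number, as does compound 1, which in this assay likewise gives "not active" (no number reported). Only compound 3 gives a number in this assay, 2150 nM. Among the measured compounds shown here, no pair of measured compounds differs in just one place, so no step within the measured set can be quoted.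

Compound 4 `CCCc1ccc(-c2ccc(NCc3ccccc3O)cc2)cc1` is not yet measured. It differs from compound 2 as follows: propyl in place of cyano on an aromatic carbon. The change keeps the shared core of compound 2 and exchanges only the group on the aromatic carbon para to the large group.

With compound 2 reported without a number in this assay, the size of the step to compound 4 cannot be set against a measured value; a shift in either direction is possible, and a further entry without a number is likely. For compound 4 in this assay the half-maximal effective concentration is estimated at 4000 nM, with a range of 800 nM to 20000 nM.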

Compound 4, half-maximal effective concentration: 2390 nM
The estimate for compound 4 lay 1.7-fold (0.22 log units) above the measured number, within the range that was stated.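

Among the compounds shown here, compound 2 carries no number while compound 4 does, so no step between them can be read. The compounds shown leave open how far propyl in place of cyano shifts the half-maximal effective concentration. No measured property bears on this result.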